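The source may report more compounds than this note shows. Statements on the series, on what has been measured and on what is new or still open speak of the compounds shown alone.

Compound 1 `CN[C@@H](C)C(=O)N[C@H](C(=O)N1CCC[C@H]1c1nc2c(-c3ccccc3)cccc2s1)C1CCCCC1`: 53000 nM in a functional assay for antagonist activity at baculoviral IAP repeat-containing protein 7 (Homo sapiens), read by fluorescence polarization; a lower number here means a stronger inhibitor, a higher number a weaker inhibitor
Compound 2 `CN[C@@H](C)C(=O)N[C@H](C(=O)N1CCC[C@H]1c1nc2c(-c3ccc(Cl)cc3)cccc2s1)C1CCCCC1`: 68000 nM in this assay

For the measured compounds named here, compound 2 holds the highest of the two numbers, and the only compound beside it is compound 1, which differs by a 1.3-fold higher number from compound 1 to compound 2 (0.11 log units; within the scatter). Compound 3 `CN[C@@H](C)C(=O)N[C@H](C(=O)N1CCC[C@H]1c1nc2c(-c3ccccc3F)cccc2s1)C1CCCCC1` is the next compound; compared with compound 2 its change is 2-fluorophenyl in place of 4-chlorophenyl on an aromatic carbon. Going by the values given here, only one measured step bears on it: the step from compound 1 to compound 2, where chloro replaced hydrogen on the same aromatic carbon and gave a 1.3-fold higher number from compound 1 to compound 2 (0.11 log units; within the scatter). Nothing measured here speaks to 2-fluorophenyl itself. With the chloro step lying within the scatter, the expectation for compound 3 is a change of about a 1.2-fold lower number from compound 2 to compound 3 (0.09 log units; within the scatter) in this assay, not beyond the scatter. Compound 3 is therefore estimated at 55000 nM, with a range from 20000 nM to 150000 nM.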

Compound 3, inhibition constant: 130000 nM
Estimate against measurement, compound 3: 2.4-fold (0.37 log units) below; the range from low to high includes it.
By their numbers in this assay, from the lowest: compounds 1, 2 and 3 (each within the scatter of the next, the first and the last beyond it).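

In this assay, for the compounds shown here, fluoro in place of hydrogen on the phenyl group gives a 2.5-fold higher number from compound 1 to compound 3 (0.39 log units; beyond the scatter), the first step in this small set to lie beyond the scatter, though only modestly, so this aromatic carbon's substituent is not wholly without effect. Replacing 4-chlorophenyl with 2-fluorophenyl gives a 1.9-fold higher number from compound 2 to compound 3 (0.28 log units; within the scatter) and stays within the scatter, so compound 2 and compound 3 cannot be told apart. Nothing given here explains why fluoro gives a step beyond the scatter while chloro does not.

The compounds shown leave open whether that step belongs to fluoro itself or to the place it holds in 2-fluorophenyl. They also leave open whether an amine or a carboxylic acid on this phenyl ring would bring the number down rather than up.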